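Aryl substituent changes on a cyanopyridone modulator series

The source may hold more compounds than are shown below. What is called first, only, known or untested is meant among the compounds shown, and "the series" means these compounds.

Measured compounds:
compound 1 `COc1ccc(-c2ccn(CCC(C)C)c(=O)c2C#N)cc1` gives 1150 nM
compound 2 `COc1cccc(-c2ccn(CCC(C)C)c(=O)c2C#N)c1` gives 3170 nM
compound 3 `COc1ccc(-c2ccn(CCC(C)C)c(=O)c2C#N)cc1Cl` gives 363 nM

All three share a common core and differ only in the substitution of the pendant aromatic ring. In a functional assay on CHO cells for positive allosteric modulation of metabotropic glutamate receptor 2 (Homo sapiens), read by scintillation counting and GTPgammaS binding, with a stated time of 30 min (a higher number here means that more compound is needed for the effect, a lower number that less compound is needed), compound 3 stands lowest of the three numbers; compound 1 lies closest to it, and compound 2 furthest away. Among the compounds with values here, the single one-place step measured so far runs from compound 1 to compound 3: a 3.2-fold lower number from compound 1 to compound 3 (0.50 log units; beyond the scatter), a step beyond the scatter.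

Compound 4 `COc1ccc(-c2ccn(CCC(C)C)c(=O)c2C#N)cc1OC` is not yet measured. It differs from compound 3 by methoxy in place of chloro on an aromatic carbon. Only the chloro-for-hydrogen step bears on this position, and it tells nothing about a methoxy there. Compound 2, which carries its single methoxy at a different position, gives the highest number of the set, while compound 1 with one methoxy sits in between; neither pair forms a single-place step to compound 4. A move back toward the region of compound 1 is therefore expected, as a 2.5-fold higher number from compound 3 to compound 4 (0.39 log units; beyond the scatter), with wide uncertainty. The estimate for compound 4 in this assay is 900 nM, ranging from 300 nM to 3000 nM.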

Compound 4, half-maximal effective concentration: 260 nM
Compound 4: middle estimate off by 3.5-fold (0.54 log units), on the high side; the measured number lies below the stated range.
By their numbers in this assay, from the lowest: compounds 4 and 3 (each within the scatter of the next); then compound 1; then compound 2.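

At this place, ortho to a methoxy group, chloro and methoxy cannot be told apart in this assay (a 1.4-fold lower number from compound 3 to compound 4 (0.14 log units; within the scatter)), so the step seen with chloro (a 3.2-fold lower number from compound 1 to compound 3 (0.50 log units; beyond the scatter)) is not confined to that one group. A second methoxy also gives a step beyond the scatter from either single-methoxy compound (a 4.4-fold lower number from compound 1 to compound 4 (0.65 log units; beyond the scatter); a 12-fold lower number from compound 2 to compound 4 (1.09 log units; beyond the scatter)), and the step from compound 2 is the large one. Nothing at hand gives a reason for these steps.

From the compounds shown here alone, with only chloro and methoxy at this place, it remains open whether an ethoxy group, a longer chain or an amine there would keep the number near that of compound 4. Going by these compounds, it also remains open whether any of these steps would hold with a different chain on the shared core.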